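The source may report more compounds than this note shows. Statements on the series, on what has been measured and on what is new or still open speak of the compounds shown alone.

Measured so far:
- compound 1, `O=C(NO)c1ccc2c(c1)CCN(S(=O)(=O)c1cc(F)c(F)c(F)c1F)C2`: 1540 nM
- compound 2, `O=C(NO)c1ccc(CN(C2CC2)S(=O)(=O)c2cc(F)c(F)c(F)c2F)cc1`: 480 nM

Both compounds were tested in a functional assay on MM1.S cells (Homo sapiens) for inhibition, with a stated time of 72 h; a higher number here means a weaker inhibitor, a lower number a stronger inhibitor. Compound 2 stands at the lower of the two numbers, and compound 1 sits at a higher number, a gap that lies beyond the usual scatter of repeated measurements. Going by the values given here, the two structures differ in more than one place, so no single step between them is counted here; only what the two values show can be said.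

Compound 3, `CC(C)N(Cc1ccc(C(=O)NO)cc1)S(=O)(=O)c1cc(F)c(F)c(F)c1F`, has not been measured yet. It differs from compound 2 in one place: isopropyl in place of cyclopropyl on a sulfonamide nitrogen. The rest of the molecule, the hydroxamic acid, the benzyl linker and the sulfonamide with its tetrafluorophenyl ring, stays as it is. Among the compounds with values here, nothing among the measured compounds speaks to this exchange of a small ring for a small chain, and the change is slight in size. The expected step is therefore a 1.1-fold higher number from compound 2 to compound 3 (0.03 log units; within the scatter), a shift that stays within the usual scatter. For compound 3 the estimate in this assay is 520 nM, with a likely range from 220 nM to 1250 nM.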

Compound 3, half-maximal inhibitory concentration: 1380 nM
The estimate for compound 3 lay 2.7-fold (0.42 log units) below the measured number; measured number outside the range, above it.
By their numbers in this assay, from the lowest: compound 2; then compounds 3 and 1 (each within the scatter of the next).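

Cyclopropyl and isopropyl on this sulfonamide nitrogen each bring 3 heavy atoms, all carbon, and no hydrogen-bond donor or acceptor, yet in this assay the exchange gives a 2.9-fold higher number from compound 2 to compound 3 (0.46 log units; beyond the scatter) and so lies beyond the scatter. This position therefore responds to a change that leaves those counts untouched and removes only the three-membered ring, something compounds 1 and 2 could not show, as they differ in more than one place. No measurement at hand gives a reason for this step.

The compounds shown leave open whether the ring itself is what counts here, since a larger ring such as cyclobutyl, a straight propyl chain or a single methyl on this nitrogen could land near compound 2, near compound 3 or elsewhere. They also leave open whether the same exchange would give a step of similar size if the tetrafluorophenyl ring were replaced by a plain phenyl ring.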